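Cytotoxicity notes: N-methylation across two aminoazine cores

A few compounds are considered here, and "the series" means these few. Any claim that something is new, unique, unknown or untested is made for them only; others in the source may bear on it.

Measured compounds in an ADME assay on MT2 cells (Homo sapiens) for cytotoxicity; a lower number here means that less compound is tolerated, a higher number that more compound is tolerated:
- compound 1 `CC(C)=CCOc1cc(Nc2ncnc(N)n2)ccc1Cl` gives 48000 nM
- compound 2 `CNc1ncnc(Nc2ccc(Cl)c(OCC=C(C)C)c2)n1` gives 3100 nM
- compound 3 `CC(C)=CCOc1cc(Nc2nccc(N)n2)ccc1Cl` gives 500 nM

The two cores differ as described by 4-aminopyrimidin-2-yl in place of 4-amino-1,3,5-triazin-2-yl on a nitrogen on an aromatic ring, and that exchange gives a 96-fold lower number from compound 1 to compound 3 (1.98 log units; beyond the scatter). Within the core of compound 1, the change methyl in place of hydrogen on a nitrogen on an aromatic ring gives a 15-fold lower number from compound 1 to compound 2 (1.19 log units; beyond the scatter).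

Compound 4 `CNc1ccnc(Nc2ccc(Cl)c(OCC=C(C)C)c2)n1` is not yet measured. It carries the change methyl in place of hydrogen on a nitrogen on an aromatic ring relative to compound 3, the same change as from compound 1 to compound 2, and in both cases the place reads the same: on a nitrogen on an aromatic ring whose other neighbours are aromatic carbon.

For compound 4 a step of about an 8.3-fold lower number from compound 3 to compound 4 (0.92 log units; beyond the scatter) is expected, somewhat smaller than the earlier one, because compound 3 gives 500 nM, already the lowest value of the set. Compound 4 is estimated at 60 nM, with a likely range from 15 nM to 250 nM.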

Compound 4, half-maximal cytotoxic concentration: 690 nM
Beside the measured number, compound 4's estimate is 12-fold (1.06 log units) below it, and the stated range ends below it.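

In this assay methyl in place of hydrogen on a nitrogen on an aromatic ring gives a 1.4-fold higher number from compound 3 to compound 4 (0.14 log units; within the scatter) and so stays within the scatter on this core. The compounds shown do not reveal which feature of either core sets the outcome, or how the change would read on a further core. The step therefore does not carry from the core of compound 1 to the core of compound 3, as the two steps differ: the same change on two cores in this assay, a 15-fold lower number (1.19 log units; beyond the scatter) from compound 1 to compound 2 and a 1.4-fold higher number (0.14 log units; within the scatter) from compound 3 to compound 4, 21-fold (1.33 log units) apart, beyond the scatter of two such steps

Still open, from the compounds shown here alone, is how ethyl or a longer chain on the same nitrogen would read on each core. Dimethylamino in place of the amino group is equally open on both.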